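The compounds below may be only part of what the source reports. "The series", "measured", "known", "first", "only" and "open" are said of these compounds alone.

Measured compounds:
compound 1 `CC(=O)Oc1ccc(-c2ccc(F)cc2F)cc1C(=O)O` — 13.7% in a functional assay on the whole organism (Ear) for inhibition, with Mus musculus as the target, at a dose of 40 mg/kg by the oral route; on this read-out higher numbers stand for more inhibition at the one dose given (going by the name of the read-out) and lower numbers for less inhibition
compound 2 `CC(=O)Oc1ccc(-c2ccc(F)cc2F)cc1C(=O)Nc1ccc(Cl)cc1` — 0%

Compound 2 stands lowest of the two numbers; its nearest neighbour is compound 1, the difference being a number 13.7 percentage points lower from compound 1 to compound 2 (beyond the scatter). Compound 3 `CC(=O)Oc1ccc(-c2ccc(F)cc2F)cc1C(=O)Nc1cc(C)ccc1C` differs from compound 2 by 2,5-dimethylphenyl in place of 4-chlorophenyl on an amide-type nitrogen. Going by the values given here, no measured step changes the aryl group on the amide-type nitrogen, so the single step from compound 1 to compound 2, which exchanges the hydroxy for the anilino group, does not speak to this change. Compound 3 is therefore expected to stay close to compound 2, with a step of a number 5 percentage points higher from compound 2 to compound 3 (within the scatter) that need not exceed the scatter. The estimate for compound 3 is 5%, in the range 0% to 20%.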

Compound 3, a percentage reported as inhibition, in the whole organism at one dose (the size of the read-out at that dose, not a potency): 22%
Beside the measured number, compound 3's estimate is 17 percentage points below it, outside the stated range (above it).
By their numbers in this assay, from the lowest: compound 2; then compounds 1 and 3 (each within the scatter of the next).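

In this assay, the aryl group on the amide-type nitrogen decides the read-out: 2,5-dimethylphenyl in place of 4-chlorophenyl gives a number 22 percentage points higher from compound 2 to compound 3 (beyond the scatter). Replacing hydroxy on a carbonyl carbon with an arylamino group therefore does not always give the drop seen with compound 2, since (2,5-dimethylphenyl)amino gives a number 8.3 percentage points higher from compound 1 to compound 3 (within the scatter). No measurement at hand explains this difference. The compounds shown leave open how an unsubstituted phenyl group, a phenyl group carrying a single methyl, or a pyridyl group on the same nitrogen would read.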